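Halogen swap on a shared thiosemicarbazone core

This account rests on a few compounds, and the source may have more. Where it says the series, first, only, none or still open, it means among the compounds named here.

Compound 1 `C/C(=N\NC(=S)Nc1ccc(Cl)cc1)c1ccccn1` and compound 2 `C/C(=N\NC(=S)Nc1ccc(I)cc1)c1ccccn1` share the same core and differ only in the halogen carried on the aryl ring. In a functional assay on U-87MG ATCC cells (Homo sapiens) for cytotoxicity, read by MTT assay, with a stated time of 48 h (a higher number here means a weaker inhibitor, a lower number a stronger inhibitor), compound 1 gives 1.7 nM, while compound 2 gives 59 nM. The step of a 35-fold lower number from compound 2 to compound 1 (1.54 log units; beyond the scatter) corresponds to the change chloro in place of iodo on an aromatic carbon and is the only large movement seen so far in the series.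

Compound 3 `CC(=NNC(=S)Nc1ccc(I)cc1)c1ccccn1` has the same atoms and bonds as compound 2; the two differ only in how the double bond is drawn, (the two compounds have the same atoms and bonds; at least one stereo element is drawn with a configuration in one of them and without one in the other: 1 of 1 stereo elements differ; a double bond is drawn E in compound 2 and without a configuration in compound 3). In this assay compound 3 gives 59 nM, so that no change at the digits printed from compound 2 to compound 3 (within the scatter), which fits with the fact that one of compounds 2 and 3 is drawn with a defined configuration and the other without, at the place where they differ pointing to a difference in drawing rather than in substance.

Compound 4 `CC(=NNC(=S)Nc1ccc(Cl)cc1)c1ccccn1` has not yet been measured. It stands to compound 3 exactly as compound 1 stands to compound 2: the change is chloro in place of iodo on an aromatic carbon, the same change at a place described in the same words. Because a 35-fold lower number from compound 2 to compound 1 (1.54 log units; beyond the scatter) was a large drop in the number, and because no change at the digits printed from compound 2 to compound 3 (within the scatter) shows the drawn configuration to be without effect, compound 4 is expected to land close to compound 1. The step from compound 3 is estimated as a 35-fold lower number from compound 3 to compound 4 (1.54 log units; beyond the scatter). In this assay compound 4 is therefore expected to give about 1.7 nM, most likely falling between 0.6 nM and 5 nM.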

Compound 4, half-maximal inhibitory concentration: 1.7 nM
Compound 4: middle estimate and measured number agree at the digits printed, within the range that was stated.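

In this assay the chloro in place of iodo change recurs at full size, with a 35-fold lower number from compound 3 to compound 4 (1.54 log units; beyond the scatter), and it matches the earlier step: the same change on two cores in this assay, a 35-fold lower number (1.54 log units; beyond the scatter) from compound 2 to compound 1 and a 35-fold lower number (1.54 log units; beyond the scatter) from compound 3 to compound 4, 1.0-fold (0.00 log units) apart, within the scatter of two such steps. The agreement is less independent than two cores would suggest, as no change at the digits printed from compound 1 to compound 4 (within the scatter) and the two chloro compounds have the same atoms and bonds, so the second pair repeats the first in all but the drawing of one double bond: the fact that one of compounds 1 and 4 is drawn with a defined configuration and the other without, at the place where they differ. The series therefore shows that the step holds between the drawn and undrawn forms of one structure, but it does not show the change carrying to a core with different atoms or bonds, and it gives no reason why chloro and iodo part so widely.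

Still open, as far as these compounds go, is where other groups on the same aromatic carbon would fall relative to compounds 1 and 3, for instance bromo, fluoro, methyl, an amine or a carboxylic acid. Also open, from the compounds shown here alone, is whether the chloro in place of iodo step keeps its size on a truly different core, such as one with a longer chain in place of the methyl on the shared core.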